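The source may report more compounds than this note shows. Statements on the series, on what has been measured and on what is new or still open speak of the compounds shown alone.

Of the compounds shown here, three sharing one core have been measured in an assay on isolated protein for displacement of a labelled ligand from 5-hydroxytryptamine receptor 6 (Homo sapiens); a higher number here means a weaker inhibitor, a lower number a stronger inhibitor. Compound 1 `CNCC1CCCc2cc(S(=O)(=O)c3ccccc3)ccc21` gives 0.316 nM, compound 2 `NC[C@@H]1CCCc2cc(S(=O)(=O)c3cn[nH]c3)ccc21` gives 2 nM, and compound 3 `O=C(NC[C@@H]1CCCc2cc(S(=O)(=O)c3cccc(F)c3)ccc21)[C@H]1CCCN1` gives 0.631 nM. Compound 3 thus stands second highest of the three numbers: its nearest neighbour is compound 1, whose number is lower by a margin within the scatter, while compound 2 sits higher by a margin beyond the scatter. Compound 4 `CN(C[C@@H]1CCCc2cc(S(=O)(=O)c3cccc(F)c3)ccc21)C(N)=O` differs from compound 3 in one place: carbamoyl(methyl)amino in place of ((pyrrolidin-2-yl)carbonyl)amino on a saturated chain carbon bound to a saturated ring carbon. For the measured compounds named here, no measured pair shows this change, so its effect can only be estimated. Compound 4 is expected to stay close to compound 3, with the step of a 2.4-fold higher number from compound 3 to compound 4 (0.38 log units; beyond the scatter) expected to be small and toward a somewhat higher number. The estimate for compound 4 in this assay is 1.5 nM, within a range from 0.4 nM to 6 nM.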

Compound 4, inhibition constant: 39.8 nM
Compound 4: the middle estimate sits 27-fold (1.42 log units) below what was measured; measured number above the stated range.
By their numbers in this assay, from the lowest: compounds 1 and 3 (each within the scatter of the next); then compound 2; then compound 4.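

At a saturated chain carbon bound to a saturated ring carbon, the number in this assay proved highly sensitive to the group attached: carbamoyl(methyl)amino in place of ((pyrrolidin-2-yl)carbonyl)amino gives a 63-fold higher number from compound 3 to compound 4 (1.80 log units; beyond the scatter) as a large step. For the compounds shown here, the earlier compounds offered no pair differing in one place, so this is the first measured sign of how much this position matters. Nothing at hand bears on why the step is so large.

On these data alone, it remains open which part of the change carries the step, the missing pyrrolidine ring or the added methyl on the nitrogen. An open-chain aminoacetyl group at the same place, or a carbamoylamino group without the methyl, would separate the two.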